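This account rests on a few compounds, and the source may have more. Where it says the series, first, only, none or still open, it means among the compounds named here.

Compound 2, with the structure `Fc1ccc(-c2csc(N3N=C(c4ccc(Cl)s4)CC3c3ccc(F)cc3)n2)cc1`, is one of two compounds already tested in an ADME assay on NIH3T3 cells (Mus musculus) for cytotoxicity, read by XTT assay, with a stated time of 24 h; on this read-out higher numbers stand for weaker inhibition and lower numbers for stronger inhibition. In this assay compound 2 gives > 500 ug/mL, which is a limit of the assay rather than a measured number. Compound 1, with the structure `Fc1ccc(C2CC(c3ccc(Cl)s3)=NN2c2nc(-c3ccc(C(F)(F)F)cc3)cs2)cc1`, in this assay gives > 500 ug/mL, also a limit. Going by the values given here, both values therefore sit at the limit of > 500 ug/mL in this assay, at which 2 of the 2 values shown sit, so the single measured step, a step that the two limits leave unreadable from compound 1 to compound 2, cannot be read in size or direction.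

Compound 3, with the structure `COc1ccc(-c2csc(N3N=C(c4ccc(Cl)s4)CC3c3ccc(F)cc3)n2)cc1`, differs from compound 2 by methoxy in place of fluoro on an aromatic carbon. Among the compounds with values here, no measured step here touches a methoxy group, and the one step that exists is unreadable, so the change offers no guide to a step in this assay of any particular size. Given that compound 2 reaches only a limit, compound 3 is expected to behave in the same way, with an estimated step of a number no higher from compound 2 to compound 3 (the limit leaves the size open) and an estimated value of 500 ug/mL, in the range 150 ug/mL to 1500 ug/mL.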

Compound 3, half-maximal inhibitory concentration: 103 ug/mL
For compound 3 the middle estimate is 4.9-fold (0.69 log units) above the measured one; measured number outside the range, below it.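

Methoxy on this aromatic carbon, para to a large group, is the first change shown to give a measured number in this assay, with an at least 4.8-fold lower number from compound 2 to compound 3 (0.68 log units; beyond the scatter). Set against trifluoromethyl at the same place, methoxy gives an at least 4.8-fold lower number from compound 1 to compound 3 (0.68 log units; beyond the scatter). A lower number here means stronger inhibition, so this position can affect the read-out, though each step gives only a minimum size, with the true size left open: the limit of > 500 ug/mL in this assay, at which 2 of the 3 values shown sit.

The compounds shown leave open how an amine, a hydroxyl group or a longer chain such as ethoxy would read at this place. They also leave open whether methoxy would give a similar step at another position on the shared core.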